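A longer hydroxyethoxy chain on compound 1

A few compounds are considered here, and "the series" means these few. Any claim that something is new, unique, unknown or untested is made for them only; others in the source may bear on it.

In an ADME assay on RAW264.7 cells (Mus musculus) for cytotoxicity, read by MTT assay, with a stated time of 24 h (on this read-out higher numbers stand for lower toxicity in this test and lower numbers for higher toxicity in this test), compound 1 (`CC/C=C\C[C@H]1C(=O)C=C[C@H]1CC(=O)OCC`) gives 146 uM. Compound 3 (`CC/C=C\C[C@H]1C(=O)C=C[C@H]1CC(=O)OCCOCCO`) gives 166 uM, and the measured comparison, a 1.1-fold higher number from compound 1 to compound 3 (0.06 log units; within the scatter), leaves the two level. Compound 2 (`CC/C=C\C[C@H]1C(=O)C=C[C@H]1CC(=O)OCCCC`) gives 31 uM, and that comparison reads a 4.7-fold lower number from compound 1 to compound 2 (0.67 log units; beyond the scatter). Compound 1 therefore stands level with compound 3 and clearly higher than compound 2.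

Compound 4 (`CC/C=C\C[C@H]1C(=O)C=C[C@H]1CC(=O)OCCOCCOCCO`) keeps the core of compound 1 and differs by 2-(2-hydroxyethoxy)ethoxy in place of hydrogen on a saturated chain carbon, two bonds along the chain from an oxygen next to a carbonyl group. Cut one bond further out, the same difference reads methyl to (2-(2-hydroxyethoxy)ethoxy)methyl.

Three measured steps change this same place. Among the measured compounds shown here, the closest precedent is the 2-hydroxyethoxy step to compound 3, a 1.1-fold higher number from compound 1 to compound 3 (0.06 log units; within the scatter). For the measured compounds named here, the ethyl step to compound 2 is the only one that lowers the number, and the comparison of those two compounds gives a 5.4-fold higher number from compound 2 to compound 3 (0.73 log units; beyond the scatter). Going by the values given here, compound 4 carries no ethyl in place of hydrogen, and its chain extends that of compound 3, so it is expected to follow compound 3, although no measured compound shows what the longer chain does. The expected change is a 1.1-fold higher number from compound 1 to compound 4 (0.05 log units; within the scatter), which would be no step beyond the scatter. For compound 4 the estimated value is 165 uM, with an expected range from 80 uM to 320 uM.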

Compound 4, half-maximal toxic concentration: 162 uM
Compound 4: middle estimate off by 1.0-fold (0.01 log units), on the high side; low and high end bracket the measured number.
By their numbers in this assay, from the lowest: compound 2; then compounds 1, 4 and 3 (each within the scatter of the next).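

In this assay the longer 2-(2-hydroxyethoxy)ethoxy group gives the same picture as the shorter chain of compound 3: the step from the parent ester reads a 1.1-fold higher number from compound 1 to compound 4 (0.05 log units; within the scatter) and stays inside the usual scatter. Compound 4 also shows something compound 3 alone could not, namely that 2-hydroxyethyl in place of hydrogen on an oxygen on a saturated carbon does not separate the two chains, with a 1.0-fold lower number from compound 3 to compound 4 (0.01 log units; within the scatter) as the measured step. The gap to the ethyl change of compound 2 therefore holds for this longer chain as well, at a 5.2-fold higher number from compound 2 to compound 4 (0.72 log units; beyond the scatter), leaving compound 2 as the only one of the four set apart from the others.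

No measurement shown here explains why compound 2 parts from the other three while compounds 1, 3 and 4 stay level. The compounds shown also leave open whether this level reading would hold with an amine or a carboxylic acid in place of the hydroxyl of the chain, or how a saturated carbon chain longer than that of compound 2 would read in this assay at this position.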